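The source may hold more compounds than are shown below. What is called first, only, known or untested is meant among the compounds shown, and "the series" means these compounds.

Compound 1 `N#Cc1cc2cc(-c3ccccc3)n(O)c2cc1C#N` and compound 2 `Cc1ccc(-c2cc3cc(C#N)c(C#N)cc3n2O)cc1` share one core, while compound 3 `COn1c(-c2ccccc2)c(Br)c2cc(C#N)c(C#N)cc21` and compound 4 `COn1c(-c2ccc(C)cc2)c(Br)c2cc(C#N)c(C#N)cc21` share another, and the difference between the two cores is not broken down here. In an assay on isolated protein for inhibition of Amine oxidase [flavin-containing] A (Homo sapiens), read by fluorescence and spectrophotometry, with a stated time of 20 min (on this read-out higher numbers stand for weaker inhibition and lower numbers for stronger inhibition), compound 1 gives 6920 nM. In this assay compound 2 gives 1140 nM. The change methyl in place of hydrogen on an aromatic carbon thus made a 6.1-fold lower number from compound 1 to compound 2 (0.78 log units; beyond the scatter). Compound 3 reached only a limit in this assay, namely > 100000 nM. Compound 4 carries the same change, (methyl in place of hydrogen on an aromatic carbon). Because compound 3 sits at the limit of > 100000 nM in this assay, at which 1 of the 3 values shown sits, a step of the size seen from compound 1 to compound 2 would still be expected to leave compound 4 near that limit. Compound 4 is therefore expected at 100000 nM, between 30000 nM and 300000 nM, a step of a number no higher from compound 3 to compound 4 (the limit leaves the size open), and most likely reported again only as a limit.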

Compound 4, half-maximal inhibitory concentration: > 100000 nM
Compound 4: only a limit was reported; the forecaster's own chance of this, stated with the estimate: 75%; the middle value lies on the limit itself.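

In this assay compound 4 gives > 100000 nM, which is a limit, and compound 3 also stands only at a limit, so the step between them cannot be read. The compounds shown leave open whether methyl in place of hydrogen changes inhibition at all on the core of compound 3.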